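Thiazole Acid Replaced by Alkanoic Acid at the Ring

The source may hold more compounds than are shown below. What is called first, only, known or untested is meant among the compounds shown, and "the series" means these compounds.

In a functional assay on CHO cells for agonist activity at prostaglandin E2 receptor EP4 subtype (Homo sapiens), read by HTRF and cAMP accumulation, with a stated time of 30 min (on this read-out lower numbers stand for an effect already at smaller amounts and higher numbers for an effect only at larger amounts of compound), compound 2 `O=C(O)c1csc([C@H]2CC[C@@H]3[C@@H](/C=C/[C@@H](O)COc4ccccc4)[C@H](O)C[C@@H]3O2)n1` gives 33 nM, the lowest of the two numbers shown; its nearest neighbour is compound 3 `O=C(O)c1csc([C@H]2CC[C@@H]3[C@@H](/C=C/CCOc4ccccc4)[C@H](O)C[C@@H]3O2)n1` with 1900 nM, a step of a 58-fold higher number from compound 2 to compound 3 (1.76 log units; beyond the scatter). Compound 1 `O=C(O)c1csc([C@H]2CC[C@@H]3[C@@H](/C=C/CCCOc4ccccc4)[C@H](O)C[C@@H]3O2)n1` reaches only the assay limit, > 10000 nM, in this assay. The measured steps of an at least 300-fold lower number from compound 1 to compound 2 (2.48 log units; beyond the scatter) and an at least 5.2-fold lower number from compound 1 to compound 3 (0.72 log units; beyond the scatter) both alter the side chain, whereas compound 4 `O=C(O)CCC[C@H]1CC[C@@H]2[C@@H](/C=C/[C@@H](O)COc3ccccc3)[C@H](O)C[C@@H]2O1` differs from compound 2 at the ring: 3-carboxypropyl in place of 4-carboxy-1,3-thiazol-2-yl on a saturated ring carbon. Going by the values given here, no measured step touches this position, and the side chain of compound 2 is kept intact, so only a moderate shift is expected, a step of a 1.8-fold higher number from compound 2 to compound 4 (0.26 log units; within the scatter). Compound 4 is therefore estimated at 60 nM, within a range from 10 nM to 400 nM.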

Compound 4, half-maximal effective concentration: 4600 nM
The estimate for compound 4 lay 77-fold (1.88 log units) below the measured number; the whole stated range lies below it.
By their numbers in this assay, from the lowest: compound 2; then compound 3; then compound 4. At a limit, above all of these: compound 1.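

Exchanging the ring group matters as much as changing the side chain: with the side chain of compound 2 kept, 3-carboxypropyl in place of 4-carboxy-1,3-thiazol-2-yl on the saturated ring carbon next to the ring oxygen gives a 140-fold higher number from compound 2 to compound 4 (2.14 log units; beyond the scatter) in this assay. Going by these compounds alone, the earlier compounds varied only the side chain, so this is the first sign that this position is sensitive. Nothing given here accounts for the size of this step.

From the compounds shown here alone, it remains open whether a 4-carboxyphenyl group or a longer chain such as 4-carboxybutyl at this ring carbon would bring the number back towards that of compound 2. Going by these compounds, it is also open whether an amide could stand in for the carboxylic acid.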